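Replacing the substituted pyrazole of compound 2 with a pyridine

The source may report more compounds than this note shows. Statements on the series, on what has been measured and on what is new or still open speak of the compounds shown alone.

In a physicochemical assay for solubility, read by LC-MS, in phosphate buffer, with a stated time of 24 h, at pH 7.4 (a higher number here means a more soluble compound, a lower number a less soluble compound), compound 1 (`Cn1cc(-c2cnc(NCc3c(F)ccc4c3CCO4)c3cn[nH]c(=O)c23)cn1`) gives 1000 nM and compound 2 (`CN(C)C(=O)c1cc(-c2cnc(NCc3c(F)ccc4c3CCO4)c3cn[nH]c(=O)c23)n(C)n1`) gives 3000 nM as the higher of the two numbers. Compound 3 (`Cc1nc(CN(C)C)ccc1-c1cnc(NCc2c(F)ccc3c2CCO3)c2cn[nH]c(=O)c12`) carries 6-((dimethylamino)methyl)-2-methylpyridin-3-yl in place of 3-(dimethylcarbamoyl)-1-methyl-1H-pyrazol-5-yl on an aromatic carbon of the shared core. Among the compounds with values here, no measured step tests this group directly. Within the data shown here, only one step bears on it (a 3.0-fold higher number from compound 1 to compound 2 (0.48 log units; beyond the scatter)) and it is modest, made at the same place. A similar upward step is therefore expected (a 3.0-fold higher number from compound 2 to compound 3 (0.48 log units; beyond the scatter)) in this assay with wide uncertainty. Compound 3 is estimated at 9000 nM with an expected range from 2500 nM to 40000 nM in this measurement.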

Compound 3, solubility: > 1000000 nM
Compound 3 ended at the assay's limit; the forecaster's own chance of this, stated with the estimate: 5%; at least 110-fold (2.04 log units) between middle value and limit.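

Compound 3 gives only a limit of the assay, not a number, in this assay: the limit of > 1000000 nM in this assay, at which 1 of the 3 values shown sits. With 6-((dimethylamino)methyl)-2-methylpyridin-3-yl on this aromatic carbon, the steps are an at least 330-fold higher number from compound 2 to compound 3 (2.52 log units; beyond the scatter) and an at least 1000-fold higher number from compound 1 to compound 3 (3.00 log units; beyond the scatter). Both are large, so the number at this position can move much further than a 3.0-fold higher number from compound 1 to compound 2 (0.48 log units; beyond the scatter) had shown.

The compounds shown do not separate the (dimethylamino)methyl group from the pyridine ring or its methyl group, and the full size of both steps stays unknown. On these data alone, whether a morpholine or a carboxylic acid in place of the dimethylamino group would also reach the limit remains open.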